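The compounds below may be only part of what the source reports. "The series", "measured", "known", "first", "only" and "open" are said of these compounds alone.

Working notes on the series. For the measured compounds named here, compound 1 `NC1CCC(Nc2nc(NCc3ccc(-c4ccccc4)cc3)c3ncn(C4CCCC4)c3n2)CC1` gives 530 nM in a functional assay on K562 cells (Homo sapiens) for inhibition, with a stated time of 72 h (a higher number here means a weaker inhibitor, a lower number a stronger inhibitor), and stands as the highest of the three numbers measured so far. Compound 2 `NC1CCC(Nc2nc(NCc3ccc(-c4ccco4)cc3)c3ncn(C4CCCC4)c3n2)CC1` gives 96 nM in this assay, and compound 3 `NC1CCC(Nc2nc(NCc3ccc(-c4cccc(F)c4)nc3)c3ncn(C4CCCC4)c3n2)CC1` gives 61 nM in this assay. The measured step from compound 1 to compound 2 is a 5.5-fold lower number from compound 1 to compound 2 (0.74 log units; beyond the scatter).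

Compound 4 `NC1CCC(Nc2nc(NCc3ccc(-c4cccs4)nc3)c3ncn(C4CCCC4)c3n2)CC1` has not yet been measured. It differs from compound 1 as follows: 6-(thiophen-2-yl)pyridin-3-yl in place of 4-phenylphenyl on a saturated chain carbon bound to a nitrogen on an aromatic ring. The step from compound 1 to compound 2 bears on this change directly, since it also exchanges the phenyl for a five-membered aromatic ring with one hetero atom; the six-membered ring with one hetero atom in compound 4 is the kind of ring carried by compound 3, whose value in this assay sits with that of compound 2 rather than with compound 1. The expected step for compound 4 in this assay is therefore a lower number, of about a 7.6-fold lower number from compound 1 to compound 4 (0.88 log units; beyond the scatter). Compound 4 is estimated at 70 nM in this assay, within a range of 30 nM to 160 nM.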

Compound 4, half-maximal inhibitory concentration: 100 nM
The estimate for compound 4 lay 1.4-fold (0.15 log units) below the measured number, and the stated range covers the measured number.
By their numbers in this assay, from the lowest: compounds 3, 2 and 4 (each within the scatter of the next); then compound 1.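

In this assay, 6-(thiophen-2-yl)pyridin-3-yl in place of 4-phenylphenyl gives a 5.3-fold lower number from compound 1 to compound 4 (0.72 log units; beyond the scatter) in a step where both aromatic rings of the group change at once, so a step beyond the scatter at this position is no longer confined to the furan-2-yl exchange. Thiophen-2-yl in place of 3-fluorophenyl gives a 1.6-fold higher number from compound 3 to compound 4 (0.21 log units; within the scatter) and the exchange of 4-(furan-2-yl)phenyl for 6-(thiophen-2-yl)pyridin-3-yl gives a 1.0-fold higher number from compound 2 to compound 4 (0.02 log units; within the scatter) in this assay, so the groups of compounds 2, 3 and 4 are not told apart here. Nothing shown accounts for these steps.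

The compounds shown do not separate the contribution of the thiophen-2-yl ring from that of the six-membered ring with its hetero atom. As far as these compounds go, how a carboxylic acid or a primary amine on the outer ring would behave at this position also remains open.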